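Removing the hydroxylated side chain from compound 2

A few compounds are considered here, and "the series" means these few. Any claim that something is new, unique, unknown or untested is made for them only; others in the source may bear on it.

Of the compounds shown here, three of a shared core have been measured in an assay on TT cells for inhibition of proto-oncogene tyrosine-protein kinase receptor Ret variant C634W (Homo sapiens), read by MTT assay, with a stated time of 10 days; a lower number here means a stronger inhibitor of growth, a higher number a weaker inhibitor of growth. Compound 1 `CC(C)n1nc(-c2ccon2)c2c(N)ncnc21` gives 7920 nM. Compound 2 `CC(C)(O)Cn1nc(-c2cc(C3CC3)on2)c2c(N)ncnc21` gives 4250 nM. Compound 3 `CC(C)n1nc(/C=N/OCc2ccccc2)c2c(N)ncnc21` gives 9270 nM. On these numbers compound 2 stands lowest, but its gap to compound 1 lies within the usual scatter of such measurements, so no order between those two can be read; only its gap to compound 3 lies beyond the scatter.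

Compound 4 `Cn1nc(-c2cc(C3CC3)on2)c2c(N)ncnc21` has not yet been measured. It differs from compound 2 in one place: hydrogen in place of 1-hydroxy-1-methylethyl on a saturated chain carbon bound to an aromatic nitrogen. For the measured compounds named here, compounds 1 and 3 differ from compound 2 in more than one place, so their values give no direct reading of this particular change, and no measured pair shows it.

Without a measured step to lean on, a modest move toward weaker growth inhibition is expected for compound 4, since all three measured numbers sit in a narrow band and nothing points to a large jump in either direction. The step of a 1.6-fold higher number from compound 2 to compound 4 (0.22 log units; within the scatter) is expected to be small and may well fall within the scatter. Compound 4 is therefore estimated at 7000 nM, with a plausible range from 2500 nM to 20000 nM.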

Compound 4, concentration for 50% growth inhibition: 3510 nM
Beside the measured number, compound 4's estimate is 2.0-fold (0.30 log units) above it; the range from low to high includes it.
By their numbers in this assay, from the lowest: compounds 4, 2, 1 and 3 (each within the scatter of the next, the first and the last beyond it).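

For the compounds shown here, this is the first pair in the set that differs in one place, so the effect of a change on the saturated chain carbon bound to an aromatic nitrogen can be read directly. Going from 2-hydroxy-2-methylpropyl to methyl in this assay gives a 1.2-fold lower number from compound 2 to compound 4 (0.08 log units; within the scatter), which means the two compounds cannot be told apart in this test, even though the 1-hydroxy-1-methylethyl part and its hydrogen-bond donor and acceptor are gone. Nothing among the data shown explains why the two compounds read alike.

From the compounds shown here alone, two groups at one place cannot show how much this position tolerates, so it remains open whether an amine, a carboxylic acid or a longer chain on that carbon would move the number beyond the scatter, in either direction. Going by these compounds, it also remains open whether swapping 2-hydroxy-2-methylpropyl for methyl would read the same way on a compound whose other parts differ from those shared by compound 2 and compound 4.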